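Swapping the chlorophenyl position on a thioester amide series

A few compounds are considered here, and "the series" means these few. Any claim that something is new, unique, unknown or untested is made for them only; others in the source may bear on it.

Compound 1 `CC(=O)SCCC(CCCCC(=O)Nc1ccccc1Cl)SC(C)=O`: 6.61%
Compound 2 `CC(=O)SCCC(CCCCC(=O)Nc1cccc(Cl)c1)SC(C)=O`: 3.72%
Compound 3 `O=C(CCCCC(CCSC(=O)c1ccccc1)SC(=O)c1ccccc1)Nc1ccccc1Cl`: 5.72%

These three compounds were tested in a functional assay on Bel-7402 cells (Homo sapiens) for inhibition, read by MTT assay, with a stated time of 24 h, tested at 0.1 ug/mL; on this read-out higher numbers stand for more inhibition of growth at the one concentration tested and lower numbers for less inhibition of growth. In this assay compound 1 gives 6.61%, and the change 3-chlorophenyl in place of 2-chlorophenyl on an amide-type nitrogen gave a number 2.9 percentage points lower from compound 1 to compound 2 (within the scatter). Compound 3 gives 5.72%; how its core differs from that of compound 1 is not broken down here. Compound 4 `O=C(CCCCC(CCSC(=O)c1ccccc1)SC(=O)c1ccccc1)Nc1cccc(Cl)c1` carries the same change on the core of compound 3, namely (3-chlorophenyl in place of 2-chlorophenyl on an amide-type nitrogen). Because the step of a number 2.9 percentage points lower from compound 1 to compound 2 (within the scatter) was small, a similarly small step is expected here as well. The expected step from compound 3 to compound 4 is a number 2.2 percentage points lower from compound 3 to compound 4 (within the scatter). Compound 4 is thus estimated to give 3.5% in this assay.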

Compound 4, percent growth inhibition at one concentration: 1.7%
Compound 4: middle estimate off by 1.8 percentage points, on the high side; low and high end bracket the measured number.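

On the core of compound 3, 3-chlorophenyl in place of 2-chlorophenyl on an amide-type nitrogen gave a number 4 percentage points lower from compound 3 to compound 4 (within the scatter) in this assay. As far as this read-out can tell, the change carries over alike between the two cores: the same change on two cores in this assay, a number 2.9 percentage points lower (within the scatter) from compound 1 to compound 2 and a number 4 percentage points lower (within the scatter) from compound 3 to compound 4, 1.1 percentage points apart, within the scatter of two such steps

Both steps lie within the scatter, however, so they do not show that the change has any real effect on growth inhibition, and two small steps say little about how it would behave on other cores.

The compounds shown leave open what a plain phenyl group on the amide-type nitrogen would give. They also leave open the effect of free thiols in place of the thioesters, or of a longer chain.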